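Swapping a Hydroxypiperidine Side Chain for a Cyclobutyl Amide

A few compounds are considered here, and "the series" means these few. Any claim that something is new, unique, unknown or untested is made for them only; others in the source may bear on it.

Three compounds share one core and differ only in the side chain on the ring. Compound 1 `Cn1ncc(Cl)c1-c1cc(C(=O)N[C@@H]2CN[C@H](CCN3CCC(O)CC3)C[C@H]2c2ccc(Cl)c(Cl)c2)oc1Cl` gives 1140 nM in a functional assay on LNCaP cells (Homo sapiens) for antiproliferative activity (a higher number here means a weaker inhibitor, a lower number a stronger inhibitor), the highest number of the three. Compound 2 `Cn1ncc(Cl)c1-c1cc(C(=O)N[C@@H]2CN[C@H](CCCO)C[C@H]2c2ccc(Cl)c(Cl)c2)oc1Cl` gives 210 nM, and compound 3 `Cn1ncc(Cl)c1-c1cc(C(=O)N[C@@H]2CN[C@H](CC(=O)NCC(O)CO)C[C@H]2c2ccc(Cl)c(Cl)c2)oc1Cl` gives 660 nM. The steps are a 5.4-fold lower number from compound 1 to compound 2 (0.73 log units; beyond the scatter), a 1.7-fold lower number from compound 1 to compound 3 (0.24 log units; within the scatter) and a 3.1-fold higher number from compound 2 to compound 3 (0.50 log units; beyond the scatter).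

Compound 4 `Cn1ncc(Cl)c1-c1cc(C(=O)N[C@@H]2CN[C@H](CC(=O)NC3CCC3)C[C@H]2c2ccc(Cl)c(Cl)c2)oc1Cl` is made from compound 1 by the change (cyclobutylcarbamoyl in place of (4-hydroxypiperidin-1-yl)methyl on a saturated chain carbon bound to a saturated ring carbon). The closest guide is the move to compound 3, which also puts a carbamoyl in place of the same group and stays within the scatter. The move to compound 2 shows a larger drop, but that change is different. The cyclobutyl amide has no free hydroxyl, unlike compounds 2 and 3, so nothing measured covers it directly. A small step, if any, is expected, most likely toward a slightly lower number, as a 1.8-fold lower number from compound 1 to compound 4 (0.24 log units; within the scatter). Compound 4 is therefore estimated at 650 nM, with a range from 250 nM to 1700 nM.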

Compound 4, half-maximal inhibitory concentration: 80 nM
For compound 4 the middle estimate is 8.1-fold (0.91 log units) above the measured one; measured number outside the range, below it.
By their numbers in this assay, from the lowest: compound 4; then compound 2; then compounds 3 and 1 (each within the scatter of the next).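

In this assay the amide on this side chain does not set the number by itself: cyclobutyl in place of 2,3-dihydroxypropyl on the amide nitrogen gives an 8.3-fold lower number from compound 3 to compound 4 (0.92 log units; beyond the scatter) and so separates two compounds that looked alike in their carbamoyl link. The cyclobutylcarbamoyl change reaches much further than the earlier swap for the hydroxypiperidine chain, with a 14-fold lower number from compound 1 to compound 4 (1.15 log units; beyond the scatter) and also a 2.6-fold lower number from compound 2 to compound 4 (0.42 log units; beyond the scatter) against the plain hydroxyl chain, which leaves compound 4 with the lowest number of the four. Nothing measured here explains these steps.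

The compounds shown cannot tell whether the cyclobutyl ring matters or only the absence of the two hydroxyl groups, which a simple ethyl or a cyclopentyl on the amide nitrogen would test. On these data alone, how a longer chain before the amide would behave also remains open.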